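The source may report more compounds than this note shows. Statements on the series, on what has been measured and on what is new or still open speak of the compounds shown alone.

Measured compounds:
compound 1, `COc1nc(N)nc2c1c(-c1cccs1)cn2[C@@H]1O[C@H](CO)[C@@H](O)[C@H]1O`, gives > 20000 nM in a functional assay on A549 cells (Homo sapiens), read by MTT assay, with a stated time of 72 h; on this read-out lower numbers stand for stronger inhibition and higher numbers for weaker inhibition.
compound 2, `COc1nc(N)nc2c1c(-c1ccoc1)cn2[C@@H]1O[C@H](CO)[C@@H](O)[C@H]1O`, gives > 20000 nM.
compound 3, `CSc1ncnc2c1c(-c1ccoc1)cn2[C@@H]1O[C@H](CO)[C@@H](O)[C@H]1O`, gives 280 nM.

The value of compound 1 is a limit of the assay, not a number. The value of compound 2 is likewise a limit. Compound 3 alone gives a number. From compound 2 to compound 1 the change is thiophen-2-yl in place of furan-3-yl on an aromatic carbon; the step that the two limits leave unreadable from compound 2 to compound 1 cannot be read, since both ends sit at the limit of > 20000 nM in this assay, at which 2 of the 3 values shown sit. How the core of compound 3 differs from the core of compound 2 is not broken down here.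

Compound 4, `CSc1ncnc2c1c(-c1cccs1)cn2[C@@H]1O[C@H](CO)[C@@H](O)[C@H]1O`, is not yet measured in this assay. It carries thiophen-2-yl in place of furan-3-yl on an aromatic carbon, the same change as from compound 2 to compound 1. The measured pair gives no readable size for this change, and the expectation therefore rests on compound 3 alone, anchored on its value of 280 nM, with a step of a 1.1-fold lower number from compound 3 to compound 4 (0.05 log units; within the scatter) expected, within the usual scatter. Compound 4 is thus estimated at 250 nM in this assay, between 80 nM and 1000 nM.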

Compound 4, half-maximal inhibitory concentration: > 20000 nM
Compound 4 was reported as a limit; the forecaster's own chance of this, stated with the estimate: 10%; middle value at least 80-fold (1.90 log units) from the limit.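

In this assay, on the core of compound 3, thiophen-2-yl in place of furan-3-yl on an aromatic carbon gives an at least 71-fold higher number from compound 3 to compound 4 (1.85 log units; beyond the scatter), so on this core the change is large and far from neutral. Compound 4 gives > 20000 nM, which is a limit of the assay and not a number. The same change on the core of compound 2 cannot be read, since both of its ends sit at a limit, so the data do not show whether the change carries over from one core to the other with a similar size, and the core of compound 3 remains the only readable case: the limit of > 20000 nM in this assay, at which 3 of the 4 values shown sit.

Open, from the compounds shown here alone, is whether thiophen-3-yl, which differs from thiophen-2-yl in its point of attachment, would read closer to compound 3 or to compound 4 on this core. Also open, going by these compounds, is how phenyl, or a furan-3-yl carrying an amine or a carboxylic acid, would read in this assay in the same place.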